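The compounds below may be only part of what the source reports. "The series", "measured", "known", "first", "only" and "open" are said of these compounds alone.

compound 1 `COc1cccc(-c2nc3c(-c4cccc(Cl)c4)n[nH]c3c(=O)n2NC(=O)c2ccccc2)c1`: 91%
compound 2 `COc1cccc(-c2nc3c(-c4ccc(Cl)cc4)n[nH]c3c(=O)n2NC(=O)c2ccccc2)c1`: 87.3%
compound 3 `COc1cccc(-c2nc3c(-c4ccco4)n[nH]c3c(=O)n2NC(=O)c2ccccc2)c1`: 49.8%

In a functional assay on HT-29 cells (Homo sapiens) for cytotoxicity, read by sulforhodamine B assay, with a stated time of 2 days, tested at 100 uM (a lower number here means less inhibition, a higher number more inhibition at the concentration tested (going by the name of the read-out)), compound 2 stands second highest of the three numbers. Compound 1 lies nearest, with a number 3.7 percentage points lower from compound 1 to compound 2 (within the scatter), and compound 3 lies furthest, with a number 37.5 percentage points lower from compound 2 to compound 3 (beyond the scatter); the remaining step is a number 41.2 percentage points lower from compound 1 to compound 3 (beyond the scatter). Compound 4 `O=C(Nn1c(CCc2ccccc2)nc2c(-c3ccc(Cl)cc3)n[nH]c2c1=O)c1ccccc1` differs from compound 2 by phenethyl in place of 3-methoxyphenyl on an aromatic carbon. Going by the values given here, none of the measured steps touches this position: all three exchange the aromatic group attached elsewhere on the shared core, so no measured step bears on the change from compound 2 to compound 4. Without a comparable precedent, a modest loss is expected rather than a gain, and the expected step is a number 17.3 percentage points lower from compound 2 to compound 4 (beyond the scatter). Compound 4 is therefore estimated at 70%, within a range from 35% to 95%.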

Compound 4, a percentage reported as inhibition, at one concentration (the size of the read-out at that concentration, not a potency): 86.5%
Estimate against measurement, compound 4: 16.5 percentage points below; the range from low to high includes it.
By their numbers in this assay, from the lowest: compound 3; then compounds 4, 2 and 1 (each within the scatter of the next).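

In this assay, the position between two ring nitrogen atoms accepted phenethyl in place of 3-methoxyphenyl with no change beyond the scatter (a number 0.8 percentage points lower from compound 2 to compound 4 (within the scatter)). Going by these compounds alone, this was the first measured change at this position, and the number held although the hydrogen-bond acceptor of the leaving group was lost and the new group joins its ring to the core through a chain. Nothing shown explains this result.

On these data alone, it remains open whether the same exchange would hold alongside furan-2-yl rather than 4-chlorophenyl. The compounds also leave open how a simple butyl chain or a chain ending in an amine would fare at this position.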